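The source may report more compounds than this note shows. Statements on the series, on what has been measured and on what is new or still open speak of the compounds shown alone.

Working notes on the series, in a physicochemical assay for solubility, in phosphate buffer, with a stated time of 2 h, at pH 7.4; a higher number here means a more soluble compound, a lower number a less soluble compound. Compound 1 (`Cc1ccc(Nc2nc(-c3ccccn3)cs2)cc1C`) gives 20000 nM and compound 2 (`COc1ccc(Nc2nc(-c3ccccn3)cs2)cc1`) gives 80000 nM as the higher of the two numbers, with a gap beyond the scatter. Going by the values given here, compound 3 (`Cc1ccc(Nc2nc(-c3ccccn3)cs2)cc1`) has no measurement yet. It departs from compound 2 in one place, with methyl in place of methoxy on an aromatic carbon, para to a large group (methyl in place of methoxy on an aromatic carbon). Among the compounds with values here, no measured pair shows this change alone, so the size of the step remains an expectation. Where compound 2 holds methoxy, compound 1 also holds methyl and gives 20000 nM at the lower end of the numbers so far. A fall beyond the scatter is therefore expected, estimated as a 2.7-fold lower number from compound 2 to compound 3 (0.43 log units; beyond the scatter) in this reading. For compound 3 the expected value is 30000 nM with an estimated range of 12000 nM to 70000 nM in this assay here.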

Compound 3, solubility: 80000 nM
For compound 3 the middle estimate is 2.7-fold (0.43 log units) below the measured one, and the stated range ends below it.
By their numbers in this assay, from the lowest: compound 1; then compounds 2 and 3 (each within the scatter of the next).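

In this assay, methyl in place of methoxy on an aromatic carbon, para to a large group, gives no change at the digits printed from compound 2 to compound 3 (within the scatter), so this swap alone does not separate the two compounds at this position. The separation appears instead with the other change, hydrogen in place of methyl on an aromatic carbon, which gives a 4.0-fold higher number from compound 1 to compound 3 (0.60 log units; beyond the scatter); the low number of compound 1 therefore goes with its additional methyl, not with the methyl that compound 3 shares with it. Nothing measured on these compounds accounts for either step.

Only methoxy and methyl are shown at the position para to the large group, so the effect of an amine or a carboxylic acid there remains open. As far as these compounds go, whether the additional methyl would give a similar step alongside methoxy also remains open.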